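This account rests on a few compounds, and the source may have more. Where it says the series, first, only, none or still open, it means among the compounds named here.

Among the measured compounds shown here, compound 1 `O=C(/C=C/c1ccc(CONC(=O)Nc2ccccc2)cc1)NO` is tested in a functional assay on CAL-27 cells (Homo sapiens) for antiproliferative activity, read by MTT assay, with a stated time of 72 h (a higher number here means a weaker inhibitor, a lower number a stronger inhibitor), and gives 62000 nM, the highest of the two numbers available, its only neighbour being compound 2 `Cc1cc(C)c(NC(=O)NOCc2ccc(/C=C/C(=O)NO)cc2)c(C)c1`, which in this assay gives 3490 nM. For the measured compounds named here, the single measured step, an 18-fold lower number from compound 1 to compound 2 (1.25 log units; beyond the scatter), is the only one that bears on compound 3 `Cc1cc(C)cc(C(=O)NOCc2ccc(/C=C/C(=O)NO)cc2)c1`, whose difference from compound 1 is 3,5-dimethylphenyl in place of anilino on a carbonyl carbon. That change is related to the measured step, since in both cases methyl-bearing aromatic carbon replaces a plain phenyl at the end of the molecule, but it is not the same: here the anilino group leaves entirely, so the nitrogen-bearing urea end of compound 1 becomes a carbonyl bearing 3,5-dimethylphenyl, and the donor counted under the difference is lost. The large size of an 18-fold lower number from compound 1 to compound 2 (1.25 log units; beyond the scatter) suggests that a lower number should be expected for compound 3, but with the change only partly overlapping, a smaller step is expected, a 6.9-fold lower number from compound 1 to compound 3 (0.84 log units; beyond the scatter). Compound 3 is therefore estimated at 9000 nM in this assay, within a range from 2500 nM to 30000 nM.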

Compound 3, half-maximal inhibitory concentration: 2240 nM
For compound 3 the middle estimate is 4.0-fold (0.60 log units) above the measured one; the whole stated range lies above it.
By their numbers in this assay, from the lowest: compounds 3 and 2 (each within the scatter of the next); then compound 1.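

In this assay, the step of a 28-fold lower number from compound 1 to compound 3 (1.44 log units; beyond the scatter) shows that the anilino group on this carbonyl carbon can leave entirely, taking its nitrogen and its hydrogen-bond donor with it, and that with 3,5-dimethylphenyl in its place the number still falls by a large step. The earlier step (an 18-fold lower number from compound 1 to compound 2 (1.25 log units; beyond the scatter)) had kept that nitrogen and exchanged only the aromatic group on it, so a lower number is now seen both with the nitrogen kept and with it gone, and the donor on this nitrogen is not needed for a low number in this assay. No measurement given here explains why either change lowers the number.

Going by these compounds, what stays open is how much of the step from the anilino group belongs to the loss of the nitrogen and how much to the two methyl groups, a question that a plain phenyl on this carbonyl carbon would separate. On these data alone, it is also open how this position would respond to a longer chain such as benzyl, or to an aromatic group carrying an amine or a carboxylic acid.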